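Swapping Methoxy for Fluoro on a Stable Compound

The compounds below may be only part of what the source reports. "The series", "measured", "known", "first", "only" and "open" are said of these compounds alone.

In an ADME assay on microsomes from liver (Mus musculus) for metabolic stability, read by LC-MS, with NADPH named in the record, with a stated time of 60 min, tested at 1 uM, in the absence of a further agent (on this read-out higher numbers stand for a more stable compound and lower numbers for a less stable compound), compound 1 `COc1ccc(-c2c(C)nc3c(N4CC[C@@H](NC(C)=O)C4)cc(C)nn23)cc1OC` gives > 95% as a limit of the assay and not a number. Compound 2 `COc1ccc(-n2c(C)nc3c(N4CC[C@@H](NC(C)=O)C4)nc(C)nc32)cc1OC` also gives > 95% as a limit of the assay. Compound 3 `COc1cc(-c2c(C)nc3c(N4CC[C@@H](NC(C)=O)C4)cc(C)nn23)ccc1F` differs from compound 1 in one place, described by fluoro in place of methoxy on an aromatic carbon as fluoro in place of methoxy on an aromatic carbon, so 3,4-dimethoxyphenyl becomes 4-fluoro-3-methoxyphenyl. Among the measured compounds shown here, no measured pair shows this change. The expected step of a number at least 3 percentage points lower from compound 1 to compound 3 (that floor lies within the scatter) is no larger than the usual scatter and has no clear direction. The estimate for compound 3 is 92% with an expected range of 78% to 100% in this measurement.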

Compound 3, percent of the compound remaining: > 95%
Compound 3: a limit, no number (the forecaster's own chance of this, stated with the estimate: 50%); at least 3 percentage points between middle value and limit.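

No step can be read from compound 1 to compound 3, because both values in this assay are limits and not numbers: the limit of > 95% in this assay, at which 3 of the 3 values shown sit.

The compounds shown leave open whether fluoro in place of methoxy changes stability at all, and in which direction.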